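A silyl ether replaces the fluoroanilino group

The compounds below may be only part of what the source reports. "The series", "measured", "known", "first", "only" and "open" are said of these compounds alone.

compound 1 `CN1C(=O)C(CCO)COC12C=CC(=O)C=C2` — > 30000 nM
compound 2 `CN1C(=O)C(CCNc2ccccc2)COC12C=CC(=O)C=C2` — > 20000 nM
compound 3 `CN1C(=O)C(CCNc2ccc(F)cc2)COC12C=CC(=O)C=C2` — 11600 nM

For the measured compounds named here, in an assay on isolated protein for inhibition of N-lysine methyltransferase SMYD2 (Homo sapiens), read by filter binding, with a stated time of 1 h (on this read-out lower numbers stand for stronger inhibition and higher numbers for weaker inhibition), compound 3 gives 11600 nM, the only actual number among the three values shown. Compound 1 reaches only a limit of the assay, > 30000 nM. Compound 2 likewise reaches only a limit, > 20000 nM. The step of an at least 2.5-fold lower number from compound 1 to compound 3 (0.41 log units; beyond the scatter) is the one clear movement; the step of an at least 1.7-fold lower number from compound 2 to compound 3 (0.23 log units; that floor lies within the scatter) is smaller, and the step that the two limits leave unreadable from compound 1 to compound 2 cannot be sized.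

Compound 4 `CN1C(=O)C(CCO[Si](C)(C)C(C)(C)C)COC12C=CC(=O)C=C2` differs from compound 3 as follows: a group of 8 heavy atoms (6 carbon, 1 oxygen, 1 silicon; no ring) in place of a group of 8 heavy atoms (6 carbon, 1 nitrogen, 1 fluorine; one six-membered aromatic ring of carbon only), on a saturated chain carbon, two bonds along the chain from a saturated ring carbon. Going by the values given here, the only measured step that bears on it is the one from compound 1, the compound with a hydroxy at the same place, in which an at least 2.5-fold lower number from compound 1 to compound 3 (0.41 log units; beyond the scatter) accompanied the arrival of the aromatic ring. Compound 4 gives that ring up again, so the step is expected to run the other way, towards weaker inhibition, in this assay. The expected step is a 2.6-fold higher number from compound 3 to compound 4 (0.41 log units; beyond the scatter). Compound 4 is therefore estimated at 30000 nM, with a range from 8000 nM to 100000 nM, and a real chance that only a limit is reported.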

Compound 4, half-maximal inhibitory concentration: > 30000 nM
Compound 4: a limit, no number (the forecaster's own chance of this, stated with the estimate: 65%); the middle value sits exactly at the limit.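

In this assay, putting the silyl ether on the saturated chain carbon in place of (4-fluorophenyl)amino gives an at least 2.5-fold higher number from compound 3 to compound 4 (0.41 log units; beyond the scatter). For the compounds shown here, both groups hold 8 heavy atoms, so at this place a group of that count does not by itself keep a measurable value, and the only number among the four compounds remains the one carried by the (4-fluorophenyl)amino group. Compound 4 reaches only a limit, the same one as compound 1: the limit of > 30000 nM in this assay, at which 2 of the 4 values shown sit.

The steps from compound 1 and from compound 2 to compound 4 cannot be read, so silylating the hydroxy of compound 1 shows no measurable gain or loss. The exchange in compound 4 removes the aromatic ring and the nitrogen together, which leaves open which of them goes with the measurable value of compound 3; a 4-fluorophenoxy group, which keeps the ring with oxygen in place of the nitrogen, or a cyclohexylamino group, which keeps the nitrogen without the aromatic ring, would separate the two.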